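Cyclobutyl Ether in Place of Neopentyl Ether

The source may report more compounds than this note shows. Statements on the series, on what has been measured and on what is new or still open speak of the compounds shown alone.

Compound 3 `CCc1sc(CCc2cc(OCC(C)(C)C)cc(NCc3cc(Cl)cc(NC(=O)OC(C)C)c3)n2)nc1C` sits second highest of three in an assay on cells for binding affinity to Neuropeptide Y receptor type 1 (Homo sapiens) (on this read-out lower numbers stand for stronger inhibition and higher numbers for weaker inhibition), giving 55 nM; compound 2 `CCCCCCCOc1cc(CCc2nc(C)c(CC)s2)nc(NCc2cc(Cl)cc(NC(=O)OC(C)C)c2)c1` with 72 nM lies within the scatter of it, and compound 1 `CCCCOc1cc(CCc2nc(C)c(CC)s2)nc(NCc2cc(Cl)cc(NC(=O)OC(C)C)c2)c1` with 16 nM lies furthest, as a 3.4-fold higher number from compound 1 to compound 3 (0.54 log units; beyond the scatter) shows. Compound 4 `CCc1sc(CCc2cc(OC3CCC3)cc(NCc3cc(Cl)cc(NC(=O)OC(C)C)c3)n2)nc1C` carries cyclobutyl in place of neopentyl on an oxygen on an aromatic ring. The step of a 3.4-fold higher number from compound 1 to compound 3 (0.54 log units; beyond the scatter), where a larger branched group replaced propyl on the carbon bound to the aromatic oxygen, bears most on this move; a 1.3-fold lower number from compound 2 to compound 3 (0.12 log units; within the scatter) adds that hexyl and tert-butyl there are indistinguishable. Cyclobutyl is smaller than neopentyl, so a modest move toward compound 1 is expected in this assay, with a 1.8-fold lower number from compound 3 to compound 4 (0.26 log units; within the scatter) as the estimated step. Compound 4 is therefore expected to give 30 nM, between 10 nM and 90 nM.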

Compound 4, half-maximal inhibitory concentration: 11 nM
For compound 4 the middle estimate is 2.7-fold (0.44 log units) above the measured one, and the stated range covers the measured number.
By their numbers in this assay, from the lowest: compounds 4 and 1 (each within the scatter of the next); then compounds 3 and 2 (each within the scatter of the next).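

Until now this oxygen carried only open chains, and compound 4 shows that a ring can sit there in this assay: cyclobutyl for neopentyl gives (a 5.0-fold lower number from compound 3 to compound 4 (0.70 log units; beyond the scatter)), and cyclobutyl for heptyl gives (a 6.5-fold lower number from compound 2 to compound 4 (0.82 log units; beyond the scatter)). Against butyl the ring cannot be told apart (a 1.5-fold lower number from compound 1 to compound 4 (0.16 log units; within the scatter)), so it matches the chain with the lowest number among the earlier compounds. Nothing available explains why these groups separate as they do. From the compounds shown here alone, whether cyclopropyl or cyclopentyl would keep this level remains open. So does the effect of an amine on the ring.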